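This account rests on a few compounds, and the source may have more. Where it says the series, first, only, none or still open, it means among the compounds named here.

Measured compounds:
- compound 1 `COc1cc(C2=NN(C(C)=O)C(c3cc(Cl)cc(Cl)c3)O2)cc(OC)c1OC` — 6.6%
- compound 2 `COc1cc(C(=O)N/N=C/c2cccc(C(F)(F)F)c2)cc(OC)c1OC` — 33.8%

In a functional assay on BGC-823 cells (Homo sapiens) for antiproliferative activity, read by MTT assay, tested at 5 uM (on this read-out higher numbers stand for a stronger effect at the one concentration tested and lower numbers for a weaker effect), compound 1 gives 6.6%, the lowest of the two numbers. Compound 2 gives 33.8%, the higher of the two, and its gap to compound 1 lies beyond the scatter. Among the measured compounds shown here, compound 2 is not one change away from compound 1, so no single step between measured compounds is available; the two values show only that the series spans a weak and a moderate effect at the one concentration.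

Compound 3 `COc1cc(C2=NN(C(C)=O)C(c3ccccc3C(F)(F)F)O2)cc(OC)c1OC` is the next member. It differs from compound 1 as follows: 2-(trifluoromethyl)phenyl in place of 3,5-dichlorophenyl on a saturated ring carbon. The 3,5-dichlorophenyl leaves and the 2-(trifluoromethyl)phenyl enters on the saturated ring carbon, with the rest of the shared core unchanged.

For the measured compounds named here, no measured pair isolates this change, so the expected step in this assay is small: a step from compound 1 to compound 3 of a number 6.4 percentage points higher from compound 1 to compound 3 (within the scatter), upward if anything, and quite possibly within the scatter. The estimate for compound 3 is 13%, in a range from 0% to 30%.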

Compound 3, a percentage reported as inhibition, at one concentration (the size of the read-out at that concentration, not a potency): 34.8%
Compound 3: middle estimate off by 21.8 percentage points, on the low side; measured number outside the range, above it.
By their numbers in this assay, from the lowest: compound 1; then compounds 2 and 3 (each within the scatter of the next).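

In this assay, the aryl group on the saturated ring carbon proves to be a position that can move the read-out: 2-(trifluoromethyl)phenyl in place of 3,5-dichlorophenyl gives a number 28.2 percentage points higher from compound 1 to compound 3 (beyond the scatter) with the rest of the shared core unchanged. Among the compounds shown here, this is the first step that isolates one place, and it shows that the aryl group alone can separate a weak effect from a moderate one at the single concentration tested. The two groups differ both in their substituents and in where these stand on the phenyl, and no available measurement accounts for the step, so it belongs to the exchange as a whole.

Going by these compounds, with one step at this position, it remains open whether 3,5-dichlorophenyl lowers the read-out, 2-(trifluoromethyl)phenyl raises it, or both contribute. Also open, on these data alone, is how a plain phenyl, a methoxyphenyl or a 3-(trifluoromethyl)phenyl would read on the same carbon, and whether the step would hold with a propionyl group in place of the acetyl group.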